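This account rests on a few compounds, and the source may have more. Where it says the series, first, only, none or still open, it means among the compounds named here.

Working notes on the aminopyrimidine series and its activity in an assay on CHO cells for displacement of a labelled ligand from adenosine receptor A1 (Homo sapiens), read by scintillation counting, with a stated time of 1 h, tested at 1 uM; a higher number here means more inhibition at the concentration tested (going by the name of the read-out), a lower number less inhibition.

Of the compounds shown here, three have been measured. Compound 1, `COc1cc(-c2cnc(N)nc2-c2ccccc2)cc(OC)c1OC`, gives 56% in this assay. Compound 2, `Nc1ncc(-c2ccc(O)c(Cl)c2)c(-c2ccccc2)n1`, reaches only the limit of the assay at > 80%, so no number is available for it; this is the case described in the limit of > 80% in this assay, at which 1 of the 3 values shown sits. Compound 3, `CCCCC(=O)Nc1ncc(-c2cccc(Cl)c2)c(-c2ccccc2)n1`, gives 52%, the lower of the two numbers on record, with compound 1 sitting close by, a gap that lies within the scatter of this kind of measurement. Within the data shown here, no step between measured compounds differing in a single place is available, so the shared core carries no mapped single-point change yet.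

The next compound, compound 4, `Clc1cccc(-c2cnc(NC3CCCC3)nc2-c2ccccc2)c1`, differs from compound 3 in one place: cyclopentyl in place of butylcarbonyl on a nitrogen on an aromatic ring. The change removes the carbonyl of the amide and leaves a cyclopentylamino group in its place. Among the measured compounds shown here, with no measured step of this kind on record, the size of the effect cannot be read from the data; a step of modest size in either direction, or none beyond the scatter, is the plausible range.

The estimate implies a step of a number 6 percentage points higher from compound 3 to compound 4 (within the scatter), expected to stay within the scatter. For compound 4 the expected value in this assay is 58%, with a range from 35% to 82%.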

Compound 4, a percentage reported as inhibition, at one concentration (the size of the read-out at that concentration, not a potency): > 80%
Compound 4: a limit, no number; the forecaster's own chance of this, stated with the estimate: 15%; middle value at least 22 percentage points away from the limit.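

Among these compounds, replacing butylcarbonyl with cyclopentyl on a nitrogen on an aromatic ring gives the first single-place step in this assay, and it reads a number at least 28 percentage points higher from compound 3 to compound 4 (beyond the scatter). Among the compounds shown here, this shows that the group on this nitrogen matters for the read-out, something the earlier compounds, with no single-place pair among them, could not show. For compound 4 the reading of > 80% is a limit of the assay and not a number, and the series now has more than one compound at that limit: the limit of > 80% in this assay, at which 2 of the 4 values shown sit.

The step removes the carbonyl and brings in a five-membered ring at the same time, and the compounds shown do not separate these two changes; a pentylamino group, an open chain without the carbonyl, or a cyclohexylamino group on the same nitrogen would bear on that question. From the compounds shown here alone, the full size of the step also remains open, as does whether cyclopentylamino would give a similar gain with the other groups on the shared core, such as the trimethoxyphenyl group of compound 1.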